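A few compounds are considered here, and "the series" means these few. Any claim that something is new, unique, unknown or untested is made for them only; others in the source may bear on it.

In a functional assay for inhibition, read by fluorescence and spectrophotometry, with a stated time of 30 h (on this read-out higher numbers stand for weaker inhibition and lower numbers for stronger inhibition), compound 2 `COc1ccc(-c2cc(=O)c3ccc(OCCCCN4CCC(C)CC4)cc3o2)cc1` gives 48200 nM, and compound 1 `COc1ccc(-c2cc(=O)c3ccc(OCCCN4CCC(CCO)CC4)cc3o2)cc1` gives 43200 nM. These two numbers lie within the usual scatter of each other, so neither compound can be ranked above the other.

The next compound, compound 3 `COc1ccc(-c2cc(=O)c3ccc(OCCCCCCCN4CCC(C)CC4)cc3o2)cc1`, differs from compound 2 as follows: 3-(4-methylpiperidin-1-yl)propyl in place of 4-methylpiperidin-1-yl on a saturated chain carbon, four bonds along the chain from an oxygen on an aromatic ring. The same difference can be read as (4-methylpiperidin-1-yl)methyl to 4-(4-methylpiperidin-1-yl)butyl, so the ring group stays and the chain carrying it grows.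

Among the measured compounds shown here, only one measured step bears on this, a 1.1-fold higher number from compound 1 to compound 2 (0.05 log units; within the scatter). That step also alters the chain, but it changes the group on the ring at the same time, and it offers no direction for a chain extension of this size. With so little evidence, a modest move in this assay towards a lower number is expected, although a move the other way cannot be ruled out.

The estimate amounts to a 1.9-fold lower number from compound 2 to compound 3 (0.29 log units; within the scatter), which is an expected step and not a measured one. For compound 3, the estimated value is 25000 nM, with an expected range of 6000 nM to 70000 nM.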

Compound 3, half-maximal inhibitory concentration: 61600 nM
For compound 3 the middle estimate is 2.5-fold (0.39 log units) below the measured one, within the range that was stated.
By their numbers in this assay, from the lowest: compounds 1, 2 and 3 (each within the scatter of the next).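

In this assay, among the compounds shown here, this is the first direct test of chain length alone: the 4-methylpiperidin-1-yl ring stays, the chain carrying it grows to 4-(4-methylpiperidin-1-yl)butyl, and the result is a 1.3-fold higher number from compound 2 to compound 3 (0.11 log units; within the scatter) so this added length does not separate the two compounds. The wider comparison, in which the ring group differs as well as the chain, gives a 1.4-fold higher number from compound 1 to compound 3 (0.15 log units; within the scatter) and so also leaves the two compounds unseparated; across the three compounds shown, neither the chain lengths nor the two ring groups produce a difference that stands clear of the usual scatter. Nothing available explains this flat result or links it to any property of the chain or the ring group.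

The compounds shown leave open whether a change of another kind at this position, such as a morpholin-4-yl group or a piperazin-1-yl group in place of 4-methylpiperidin-1-yl, would move the number beyond the scatter. They also leave open whether a chain carrying an amide or ending in a carboxylic acid would do so, or whether such a chain would read the same as these three.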